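Chloro removal on the ester-bearing ring of compound 3

A few compounds are considered here, and "the series" means these few. Any claim that something is new, unique, unknown or untested is made for them only; others in the source may bear on it.

Three analogues of the shared core carry measured numbers in a functional assay on cells (T-cell, Mus musculus, strain BALB/c) for inhibition, read by MTT assay, with a stated time of 72 h; on this read-out higher numbers stand for weaker inhibition and lower numbers for stronger inhibition: compound 1 `COC(=O)c1c(Cl)cc(Cl)cc1OC(=O)COc1cc(O)c2c(=O)cc(-c3ccccc3)oc2c1` gives 43600 nM, compound 2 `C=C(CCc1cc(O)c2c(=O)cc(-c3ccccc3)oc2c1)Cc1c(Br)cccc1C(=O)CC` gives 40700 nM, and compound 3 `COC(=O)c1ccc(Cl)cc1OC(=O)COc1cc(O)c2c(=O)cc(-c3ccccc3)oc2c1` gives 12400 nM. Compound 3 therefore stands lowest of the three, with compound 2 the nearest and compound 1 the furthest, both beyond the scatter. Among the compounds with values here, the one step that matches a single change runs a 3.5-fold lower number from compound 1 to compound 3 (0.55 log units; beyond the scatter), so taking away one chloro on the ester-bearing ring lowered the number modestly.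

Compound 4 `COC(=O)c1ccccc1OC(=O)COc1cc(O)c2c(=O)cc(-c3ccccc3)oc2c1` takes the same kind of change one position further: hydrogen in place of chloro on an aromatic carbon on the ring para to the methoxycarbonyl group. Within the data shown here, only the step from compound 1 to compound 3 bears on it, and it was modest, so a smaller or similar lowering, possibly within the scatter, is the reasonable expectation in this assay. Compound 4 is accordingly estimated at 7000 nM, with a range of 3000 nM to 18000 nM, which means an expected step of a 1.8-fold lower number from compound 3 to compound 4 (0.25 log units; within the scatter).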

Compound 4, half-maximal inhibitory concentration: 28500 nM
Estimate against measurement, compound 4: 4.1-fold (0.61 log units) below, outside the stated range (above it).
By their numbers in this assay, from the lowest: compound 3; then compounds 4, 2 and 1 (each within the scatter of the next).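

The same replacement of chloro by hydrogen runs in opposite directions on this ring in this assay: removing the other chloro gave a 3.5-fold lower number from compound 1 to compound 3 (0.55 log units; beyond the scatter), whereas removing the chloro para to a methoxycarbonyl group gave a 2.3-fold higher number from compound 3 to compound 4 (0.36 log units; beyond the scatter). The step from compound 1 therefore cannot be carried over from one position to the other, and the 5-chloro-2-(methoxycarbonyl)phenyl group of compound 3 gives a lower number here than the 2-(methoxycarbonyl)phenyl group of compound 4. No measurement at hand accounts for this reversal.

Still open, from the compounds shown here alone, is whether chloro itself matters at this place, or whether fluoro, bromo, methyl or methoxy would match compound 3 at 12400 nM in this assay. Also open, going by these compounds, is how this chloro would read with a carboxylic acid or an amide in place of the methyl ester.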